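Removing the nitrile from compound 3: what solubility follows

The source may hold more compounds than are shown below. What is called first, only, known or untested is meant among the compounds shown, and "the series" means these compounds.

Compound 3 `CC(C)n1nc(-c2ccc3oc(N)nc3c2)c2c(C#N)nc(N)nc21` is one of three analogues on a shared core, alongside compound 1 `CC(C)n1nc(-c2ccc3oc(N)nc3c2)c2c(CO)nc(N)nc21` and compound 2 `CC(C)n1nc(-c2ccc3oc(N)nc3c2)c2c(Cl)nc(N)nc21`. In a physicochemical assay for solubility, read by HPLC, in phosphate buffer, measured as kinetic solubility, with a stated time of 24 h, at 20 degrees C, at pH 7.4, tested at 100 uM (on this read-out lower numbers stand for lower solubility and higher numbers for higher solubility), compound 1 gives 82000 nM, and compound 2 gives 2000 nM. For compound 3 this assay reports only a limit, < 1000 nM, so compound 3 sits at the floor of the values shown (the limit of < 1000 nM in this assay, at which 1 of the 3 values shown sits). Compound 4 `CC(C)n1nc(-c2ccc3oc(N)nc3c2)c2cnc(N)nc21` carries hydrogen in place of cyano on an aromatic carbon. Among the compounds with values here, no measured step swaps in hydrogen; the nearest are an at least 82-fold lower number from compound 1 to compound 3 (1.91 log units; beyond the scatter) and an at least 2.0-fold lower number from compound 2 to compound 3 (0.30 log units; that floor lies within the scatter), which show the cyano analogue at or beyond the low end. Compound 4 is therefore expected to move modestly upward, an at least 3.0-fold higher number from compound 3 to compound 4 (0.47 log units; beyond the scatter), with a wide margin of uncertainty. The estimate for compound 4 is 3000 nM, within 800 nM to 15000 nM.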

Compound 4, solubility: 1600 nM
Compound 4: middle estimate off by 1.9-fold (0.27 log units), on the high side; measured number inside the range.
By their numbers in this assay, from the lowest: compounds 4 and 2 (each within the scatter of the next); then compound 1. At a limit, below all of these: compound 3.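

Compound 3 has only a limit of the assay, not a number: the limit of < 1000 nM in this assay, at which 1 of the 4 values shown sits. Its step, an at least 1.6-fold higher number from compound 3 to compound 4 (0.20 log units; that floor lies within the scatter), is therefore only a floor and does not settle how far cyano and hydrogen lie apart at this position. Hydrogen and chloro read alike, with a 1.3-fold lower number from compound 2 to compound 4 (0.10 log units; within the scatter), while hydroxymethyl stands apart, with a 51-fold lower number from compound 1 to compound 4 (1.71 log units; beyond the scatter), so a high reading here does not depend on simply having a heavier group than hydrogen on this aromatic carbon.

From the compounds shown here alone, it remains open whether an amine, a carboxylic acid or a longer hydroxyalkyl chain at this position would read near compound 1 or near compound 4.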